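Replacing a Branched Alkyl with 2-Methoxyphenyl on the Ring Carbon

A few compounds are considered here, and "the series" means these few. Any claim that something is new, unique, unknown or untested is made for them only; others in the source may bear on it.

Compound 3 `CCC(CC)C1C(C(=O)c2ccc(OC)cc2)=C(O)C(=O)N1c1ccc(-c2ccon2)cc1` stands lowest of the three measured compounds in an ADME assay on the whole organism (serum, Rattus norvegicus) for protein binding (a higher number here means a larger unbound share of the compound, a lower number a smaller unbound share), giving 0.0002. Compound 1 `CNC(=O)c1ccc(C(=O)C2=C(O)C(=O)N(c3ccc(-c4ccon4)cc3)C2C2CCCCC2)cc1` gives 0.007 and compound 2 `COc1ccc(C(=O)C2=C(O)C(=O)N(c3ccc(-c4ccon4)cc3)C2C2CCCCC2)cn1` gives 0.003, both well above compound 3. Compound 4 `COc1ccc(C(=O)C2=C(O)C(=O)N(c3ccc(-c4ccon4)cc3)C2c2ccccc2OC)cc1` differs from compound 3 by 2-methoxyphenyl in place of pentan-3-yl on a saturated ring carbon. Going by the values given here, the only measured step, a 2.3-fold lower number from compound 1 to compound 2 (0.37 log units; beyond the scatter), concerns the group on the carbonyl carbon and not the saturated ring carbon, so no measured step bears directly on this change. Compounds 1 and 2, which carry a ring at this position, sit higher than compound 3, and compound 4 is therefore expected to rise modestly toward them, by a 5.0-fold higher number from compound 3 to compound 4 (0.70 log units; beyond the scatter). Compound 4 is estimated at 0.001, within 0.0002 to 0.005.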

Compound 4, unbound fraction: 0.0049
The estimate for compound 4 lay 4.9-fold (0.69 log units) below the measured number; low and high end bracket the measured number.
By their numbers in this assay, from the lowest: compound 3; then compounds 2, 4 and 1 (each within the scatter of the next, the first and the last beyond it).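

With 2-methoxyphenyl in place of pentan-3-yl on the saturated ring carbon, this assay shows a 25-fold higher number from compound 3 to compound 4 (1.39 log units; beyond the scatter). Going by these compounds alone, this gives the first measured step at this position and shows that the unbound fraction responds strongly to the group placed there. Nothing available explains the size of this step. Whether the rise comes from the aromatic ring or its methoxy group stays open, since plain phenyl does not appear among these compounds. From the compounds shown here alone, how an amine or a carboxylic acid on this ring carbon would behave also remains unknown.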